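Bromo in place of chloro: working notes on the series

The compounds below may be only part of what the source reports. "The series", "measured", "known", "first", "only" and "open" are said of these compounds alone.

Compound 1 `NC1=NC2(CCSCC2)N(OCCCOc2cccc(Cl)c2)C(N)=N1`: 60 nM
Compound 2 `NC1=NC2(CCOCC2)N(OCCCOc2ccccc2Cl)C(N)=N1`: 2700 nM

Both values come from a functional assay on A549 cells (Homo sapiens) for antiproliferative activity, read by MTT assay, with a stated time of 72 h; a lower number here means a stronger inhibitor, a higher number a weaker inhibitor. Compound 2 holds the higher of the two numbers, and its gap to compound 1 lies beyond the scatter. These two compounds differ in more than one place, so that gap gives no measure of any single change.

The unmeasured compound is compound 3 (`NC1=NC2(CCOCC2)N(OCCCOc2ccccc2Br)C(N)=N1`). Its difference from compound 2 is as follows: bromo in place of chloro on an aromatic carbon. In words, this is bromo in place of chloro on an aromatic carbon, ortho to a large group.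

Among the measured compounds shown here, no measured pair shows a step of this kind. The expectation therefore starts from compound 2 at 2700 nM and from the structural change alone. In this assay no shift beyond the scatter is expected, in either direction. The expected size is a 1.1-fold lower number from compound 2 to compound 3 (0.03 log units; within the scatter). Compound 3 is estimated at 2500 nM, with an expected range from 900 nM to 7000 nM.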

Compound 3, half-maximal inhibitory concentration: 160 nM
The estimate for compound 3 lay 16-fold (1.19 log units) above the measured number; the measured number lies below the stated range.
By their numbers in this assay, from the lowest: compound 1; then compound 3; then compound 2.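

On the 2-chlorophenoxy group of compound 2, the identity of the halogen matters far more than the size of the edit suggests: in this assay bromo in place of chloro gives a 17-fold lower number from compound 2 to compound 3 (1.23 log units; beyond the scatter) for the exchange of one heavy atom for one heavy atom, with no change in ring, hydrogen-bond donors, hydrogen-bond acceptors or net charge. As the only single-place step shown, it establishes that this aromatic carbon, ortho to a large group, is sensitive to which halogen it carries, which the earlier pair could not show. Nothing shown bears on the cause of this step.

The compounds shown leave open whether iodo or methyl on this carbon would extend the step or reverse it, and where the unsubstituted phenoxy group would fall relative to compound 2 and compound 3. Also open, from the compounds shown here alone, is whether bromo in place of chloro would give a step of similar size in compound 1, where the chloro stands on a different aromatic carbon and the core also differs.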